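This account rests on a few compounds, and the source may have more. Where it says the series, first, only, none or still open, it means among the compounds named here.

Working notes on the series.

Compound 1 `CC(=O)Nc1ccc(S(=O)(=O)NNC(=O)c2cccnc2Nc2ccc(Cl)cc2)cc1` is measured in a functional assay on DU-145 cells (Homo sapiens) for antiproliferative activity; a lower number here means a stronger inhibitor of growth, a higher number a weaker inhibitor of growth. In this assay compound 1 gives > 100000 nM, which is a limit of the assay and not a number; compound 1 therefore stands at the limit of the values shown, as the limit of > 100000 nM in this assay, at which 1 of the 2 values shown sits, records. Going by the values given here, the only other measured member, compound 2 `O=C(NNS(=O)(=O)c1ccc(F)cc1)c1cccnc1Nc1ccc(Cl)cc1Cl`, gives 55000 nM in this assay, a number rather than a limit. Among the compounds with values here, no pair of measured compounds differs in a single place, so no measured step exists to lean on.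

Compound 3 `O=C(NNS(=O)(=O)c1ccc(Cl)cc1Cl)c1cccnc1Nc1ccc(Cl)cc1` is not yet measured. It differs from compound 1 by 2,4-dichlorophenyl in place of 4-acetamidophenyl on a sulfonyl sulfur. Since compound 1 shows only a limit, the size of the step to compound 3 is open. Compound 2, which carries a halogenated phenyl on its sulfonyl, gives 55000 nM, so a number in that region is expected. The step from compound 1 to compound 3 is estimated as an at least 2.5-fold lower number from compound 1 to compound 3 (0.39 log units; beyond the scatter), towards lower numbers. For compound 3 the expected value in this assay is 40000 nM, with a range from 10000 nM to 150000 nM.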

Compound 3, concentration for total growth inhibition: > 100000 nM
Compound 3 gave a limit, no number (the forecaster's own chance of this, stated with the estimate: 35%); at least 2.5-fold (0.39 log units) between middle value and limit.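

In this assay, compound 1 and compound 3 each give a limit and not a number, so no step between them can be read: the limit of > 100000 nM in this assay, at which 2 of the 3 values shown sit.

The compounds shown leave open what size of change, if any, 2,4-dichlorophenyl in place of 4-acetamidophenyl on a sulfonyl sulfur brings.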